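The compounds below may be only part of what the source reports. "The series", "measured", "known", "first", "only" and "open" are said of these compounds alone.

Measured so far in a functional assay on HL-60 cells (Homo sapiens) for cytotoxicity, read by WST assay, with a stated time of 48 h; on this read-out higher numbers stand for an effect only at larger amounts of compound and lower numbers for an effect already at smaller amounts:
- compound 1, `O=C1OC[C@H](Cc2ccccc2)[C@H]1Cc1ccccc1OC(F)(F)F`, gives 39000 nM
- compound 2, `CCCCOc1ccccc1C[C@H]1C(=O)OC[C@@H]1Cc1ccccc1`, gives 20000 nM
- compound 3, `Cc1ccccc1C[C@H]1C(=O)OC[C@@H]1Cc1ccccc1`, gives 57000 nM

Compound 3 holds the highest of the three numbers in this assay. Its nearest neighbour is compound 1, and that gap, a 1.5-fold higher number from compound 1 to compound 3 (0.16 log units; within the scatter), stays within the scatter. Within the data shown here, the gap to compound 2 is wider: a 2.9-fold higher number from compound 2 to compound 3 (0.45 log units; beyond the scatter) is a modest step beyond the scatter, the only one so far. The remaining step, a 2.0-fold lower number from compound 1 to compound 2 (0.29 log units; within the scatter), is again within the scatter.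

Compound 4, `O=C1OC[C@H](Cc2ccccc2)[C@H]1Cc1ccc(F)cc1`, is not yet measured. It differs from compound 3 thus: 4-fluorophenyl in place of 2-methylphenyl on a saturated chain carbon bound to a saturated ring carbon

The measured steps all exchange one group for another on the same aromatic ring of the shared core, and their sizes range from within the scatter to modest. None of them exchanges a 2-methylphenyl for a 4-fluorophenyl, so they bear on the new step only in showing that changes on this ring have moved this assay little. The expectation for compound 4 is therefore a step of no more than modest size in either direction, most likely none beyond the scatter; the estimated step is a 1.4-fold lower number from compound 3 to compound 4 (0.15 log units; within the scatter). Compound 4 is expected to give about 40000 nM, with a range from 15000 nM to 110000 nM.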

Compound 4, half-maximal effective concentration: 57000 nM
Estimate against measurement, compound 4: 1.4-fold (0.15 log units) below; measured number inside the range.
By their numbers in this assay, from the lowest: compounds 2, 1, 3 and 4 (each within the scatter of the next, the first and the last beyond it).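

In this assay, the step reads no change at the digits printed from compound 3 to compound 4 (within the scatter) for 4-fluorophenyl in place of 2-methylphenyl on a saturated chain carbon bound to a saturated ring carbon. Unlike the earlier steps, which exchanged one group for another on the aromatic ring, this one replaces the whole substituted phenyl group and brings in a fluorine, yet the read-out does not respond; the two groups match in heavy atom count and in having no hydrogen-bond donors or acceptors. Nothing on hand explains this lack of response.

This single step changes the substituent and the name of its ring position together, so the contribution of each remains unresolved, and the second phenyl group of the shared core carries no substituent in any of the four compounds. Also open, from the compounds shown here alone, is whether an amine or a carboxylic acid on either aromatic ring would move the number beyond the narrow spread seen so far.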